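This account rests on a few compounds, and the source may have more. Where it says the series, first, only, none or still open, it means among the compounds named here.

Compound 1 `CCOC(=O)c1ccc(NCc2cncn2Cc2ccc(-c3ccccc3)cc2)cc1-c1ccccc1` in a toxicity assay on NIH3T3 cells (Mus musculus) for cytotoxicity, read by resazurin assay (on this read-out lower numbers stand for an effect already at smaller amounts and higher numbers for an effect only at larger amounts of compound), gives > 10000 nM, which is a limit of the assay and not a number.
Compound 2 `COC(=O)c1ccc(NCc2cncn2Cc2ccccc2Br)cc1-c1ccccc1` in this assay gives 10000 nM.
Compound 3 `c1ccc(-c2ccc(Cn3cncc3CNc3ccccc3-c3ccccc3)cc2)cc1` in this assay gives > 10000 nM, again a limit of the assay rather than a number.

The three measured compounds share a core built around a benzylimidazole linked through an aminomethyl bridge to a biphenyl-type aryl amine. For compound 1 only a limit is known in this assay, and it sits at the limit of > 10000 nM in this assay, at which 2 of the 3 values shown sit. Among the compounds with values here, compound 2 reports a number at the same concentration, so across the whole set nothing separates the compounds; there is no measured step between them, and no order can be read from the values.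

Compound 4 `c1ccc(-c2ccc(Cn3cncc3CNc3ccc(-c4onc5ccccc45)c(-c4ccccc4)c3)cc2)cc1` has not yet been measured. It differs from compound 1 by a group of 9 heavy atoms (7 carbon, 1 nitrogen, 1 oxygen; one five-membered aromatic ring with 2 hetero atoms, one six-membered aromatic ring of carbon only) in place of a group of 5 heavy atoms (3 carbon, 2 oxygen; no ring), on an aromatic carbon.

Within the data shown here, since all three measured compounds fall at or near the top of the tested range, and no measured step points in either direction, the step from compound 1 to compound 4 is expected to be an at least 1.2-fold lower number from compound 1 to compound 4 (0.09 log units; that floor lies within the scatter), that is, no change beyond the usual scatter. Compound 4 is accordingly estimated to give 8000 nM in this assay, within a range from 3000 nM to 20000 nM, with a real chance that only a limit is reported again.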

Compound 4, half-maximal effective concentration: > 10000 nM
Compound 4: no number, only a limit; the forecaster's own chance of this, stated with the estimate: 50%; at least 1.2-fold (0.09 log units) between middle value and limit.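

In this assay compound 4 gives > 10000 nM, a limit of the assay and not a number. Within the data shown here, compound 1 also stands only as a limit, and no step from compound 1 to compound 4 can be read. The compounds shown leave open whether replacing ethoxycarbonyl with the larger two-ring group changes the value in this assay at all.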